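The compounds below may be only part of what the source reports. "The series", "measured", "known", "first", "only" and "open" are said of these compounds alone.

Going by the values given here, compound 2 `O=Cc1ccc(-c2cn3ccnc3c(-c3ccc4ncn(C5CCCCC5)c4c3)n2)cc1` gives 1.5 in a physicochemical assay for lipophilicity, using the shake flask method, in phosphate buffer, measured as octanol-water partition, with a stated time of 85 min, at pH 7.4 (a higher number here means a more lipophilic compound, a lower number a more polar compound), the highest of the two numbers measured so far; the nearest is compound 1 `COc1ccc(-c2cn3ccnc3c(-c3ccc4ncn(C5CCCCC5)c4c3)n2)cc1`, which in this assay gives 1.41. Among the compounds with values here, the only step between measured compounds, a number 0.09 log units higher from compound 1 to compound 2 (within the scatter), lies within the scatter, so the two values cannot be ordered.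

Compound 3 `COc1ccccc1-c1cn2ccnc2c(-c2ccc3ncn(C4CCCCC4)c3c2)n1` has not yet been measured in this assay. The change from compound 2 is 2-methoxyphenyl in place of 4-formylphenyl on an aromatic carbon. Within the data shown here, the one measured step bears on it directly: it exchanged formyl and methoxy at the same place, and from compound 1 to compound 2 the partition coefficient moved a number 0.09 log units higher from compound 1 to compound 2 (within the scatter), inside the scatter. The step to compound 3 reverses that exchange, with the methoxy now carried as 2-methoxyphenyl rather than the 4-methoxyphenyl of compound 1. Among the measured compounds shown here, no measured compound carries a 2-methoxyphenyl, so nothing tells whether this placement matters. Compound 3 is therefore expected to move a number 0.10 log units lower from compound 2 to compound 3 (within the scatter) from compound 2, a step not beyond the scatter. The estimate for compound 3 is 1.4, with a range of 1.1 to 1.7.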

Compound 3, partition coefficient: 1.72
Compound 3: the middle estimate sits 0.32 log units below what was measured; the whole stated range lies below it.
By their numbers in this assay, from the lowest: compounds 1, 2 and 3 (each within the scatter of the next, the first and the last beyond it).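

In this assay, going by these compounds alone, exchanging 4-methoxyphenyl for 2-methoxyphenyl on this aromatic carbon gives a number 0.31 log units higher from compound 1 to compound 3 (beyond the scatter), the first step to pass the scatter, though only modestly; the earlier pair could not show this, since compound 1 and compound 2 differ in the group and not in where the methoxy stands on the phenyl. The exchange of 4-formylphenyl for 2-methoxyphenyl, a number 0.22 log units higher from compound 2 to compound 3 (within the scatter), stays within the scatter, so compound 2 and compound 3 cannot be ordered, and compound 3 stands clear only of compound 1. No supporting information bears on the origin of the difference between compound 1 and compound 3.

This reading rests on a single pair with one group, so the compounds shown leave open whether the placement would matter for any substituent other than methoxy on this phenyl, such as formyl. They also leave open where a phenyl carrying an amine or a carboxylic acid at this position would fall in this assay, since all three compounds carry only a neutral group with no hydrogen-bond donor.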